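A few compounds are considered here, and "the series" means these few. Any claim that something is new, unique, unknown or untested is made for them only; others in the source may bear on it.

Measured in a functional assay on BXPC-3 cells (Homo sapiens) for inhibition, read by MTT assay, with a stated time of 72 h; a lower number here means a stronger inhibitor of growth, a higher number a weaker inhibitor of growth:
- compound 1 `O=S(=O)(NCCCNCC1COc2ccccc2O1)c1cc(C(F)(F)F)cc(C(F)(F)F)c1` gives 1200 nM
- compound 2 `O=S(=O)(NCCCNCc1ccc(C(F)(F)F)cc1)c1cc(C(F)(F)F)cc(C(F)(F)F)c1` gives 1700 nM
- compound 3 `O=S(=O)(NCCCNCc1ccc(-c2ccccc2)cc1)c1cc(C(F)(F)F)cc(C(F)(F)F)c1` gives 1700 nM

All three compounds share the same core and differ only in the group carried on the saturated chain carbon bound to the amine nitrogen. Compound 3 stands level with compound 2 at the digits printed, and the two together hold the highest numbers of the three; the nearest neighbour of compound 3 is compound 2, the furthest is compound 1, whose number is lower by an amount that stays within the scatter.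

Compound 4 `COc1ccc(CNCCCNS(=O)(=O)c2cc(C(F)(F)F)cc(C(F)(F)F)c2)cc1` differs from compound 3 by methoxy in place of phenyl on an aromatic carbon. Among the measured compounds shown here, two measured steps bear on this change, since both alter the same end of the molecule: from compound 1 to compound 2 the number changed by a 1.4-fold higher number from compound 1 to compound 2 (0.15 log units; within the scatter), and from compound 2 to compound 3 by no change at the digits printed from compound 2 to compound 3 (within the scatter). For the measured compounds named here, neither step left the scatter, so the assay so far appears indifferent to what sits at this position.

On that basis the step from compound 3 to compound 4 is expected to be a 1.1-fold lower number from compound 3 to compound 4 (0.05 log units; within the scatter), that is, nothing beyond the scatter. Compound 4 is therefore estimated at 1500 nM in this assay, with a range from 700 nM to 3500 nM.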

Compound 4, concentration for 50% growth inhibition: 1300 nM
Beside the measured number, compound 4's estimate is 1.2-fold (0.06 log units) above it, and the stated range covers the measured number.
By their numbers in this assay, from the lowest: compounds 1, 4, 2 and 3 (each within the scatter of the next).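

In this assay, this position on the aromatic ring now tolerates a change in kind: an entire phenyl ring gives way to methoxy, a group with no ring that brings in a hydrogen-bond acceptor, and the result is a 1.3-fold lower number from compound 3 to compound 4 (0.12 log units; within the scatter). Methoxy in place of trifluoromethyl at the same carbon gives a 1.3-fold lower number from compound 2 to compound 4 (0.12 log units; within the scatter), and a comparison with the ring system of compound 1 gives a 1.1-fold higher number from compound 1 to compound 4 (0.03 log units; within the scatter), so all three new steps stay within the scatter and the four compounds cannot be ranked. Nothing available here explains why such different groups give such similar numbers.

From the compounds shown here alone, it remains open whether any group at this aromatic carbon can move the number beyond the scatter, for example an amine or a carboxylic acid, both of which differ in kind from phenyl, trifluoromethyl and methoxy. The shared core also holds its own questions, such as what a longer chain in the linker, or replacement of the two trifluoromethyl groups on the other ring, would do in this assay.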